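A few compounds are considered here, and "the series" means these few. Any claim that something is new, unique, unknown or untested is made for them only; others in the source may bear on it.

Measured in an ADME assay on CCRF-HSB-2 cells (Homo sapiens) for cytotoxicity, with a stated time of 7 days; a lower number here means that less compound is tolerated, a higher number that more compound is tolerated:
Compound 1 `CCCCCCCCSc1nc(N)nc2c1ncn2/C=C1/CC1(CO)CO`: 60000 nM
Compound 2 `CCCCCCOc1nc(N)nc2c1ncn2/C=C1/CC1(CO)CO`: > 20000 nM
Compound 3 `CCCCSc1nc(N)nc2c1ncn2/C=C1/CC1(CO)CO`: 89000 nM

Compound 2 is reported only as a limit, > 20000 nM. That leaves two readable numbers, separated by only a 1.5-fold higher number from compound 1 to compound 3 (0.17 log units; within the scatter). Compound 4 `CCCCNc1nc(N)nc2c1ncn2/C=C1/CC1(CO)CO` carries butylamino in place of butylsulfanyl on an aromatic carbon. Among the compounds with values here, no measured step makes this exchange. Within the data shown here, the one readable step changes only the chain length, and a step that the limit leaves unreadable from compound 2 to compound 3 gives no size to work from. Taking compound 3 at 89000 nM as the anchor, no change beyond the scatter is expected in this assay, and neither direction is favoured. The expected result is a 1.1-fold lower number from compound 3 to compound 4 (0.05 log units; within the scatter). Compound 4 is estimated at 80000 nM, with an expected range of 25000 nM to 250000 nM.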

Compound 4, half-maximal cytotoxic concentration: > 20000 nM
Compound 4: only a limit was reported; the forecaster's own chance of this, stated with the estimate: 35%; the middle value does not contradict the limit.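

In this assay compound 4 is reported only as a limit, > 20000 nM. Its steps from compound 1, compound 2 and compound 3 therefore cannot be read: the limit of > 20000 nM in this assay, at which 2 of the 4 values shown sit. The compounds shown leave open how butylamino compares with butylsulfanyl in this core.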